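A few compounds are considered here, and "the series" means these few. Any claim that something is new, unique, unknown or untested is made for them only; others in the source may bear on it.

Measured compounds in this assay:
compound 1, `O=C(Nc1ccc(-n2ncc3c(Cl)cccc32)cc1)Nc1ccc(Cl)c(C(F)(F)F)c1`: 1600 nM
compound 2, `O=C(Nc1ccc(-n2ncc3c(Br)cccc32)cc1)Nc1ccc(Cl)c(C(F)(F)F)c1`: 7700 nM
compound 3, `O=C(Nc1ccc(-n2ncc3c(F)cccc32)cc1)Nc1ccc(Cl)c(C(F)(F)F)c1`: 3100 nM

In a functional assay on MDA-MB-231 cells (Homo sapiens) for cytotoxicity, read by MTT assay, with a stated time of 72 h (a higher number here means a weaker inhibitor, a lower number a stronger inhibitor), compound 2 gives the highest number of the three. Compound 3 stands nearest to it with 3100 nM, and compound 1 furthest with 1600 nM; both gaps lie beyond the scatter.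

Compound 4, `Cc1cccc2c1cnn2-c1ccc(NC(=O)Nc2ccc(Cl)c(C(F)(F)F)c2)cc1`, differs from compound 2 in one place: methyl in place of bromo on an aromatic carbon. Among the compounds with values here, two measured steps bear on this change, since both remove bromo from the same position of the shared core: a 2.5-fold lower number from compound 2 to compound 3 (0.40 log units; beyond the scatter), and the reverse of a 4.8-fold higher number from compound 1 to compound 2 (0.68 log units; beyond the scatter). Both removals of bromo gave a lower number, of modest size. Within the data shown here, no measured step exchanges a halogen for methyl at this position, so the transfer to compound 4 is indirect and the direction is taken from the halogen pair alone.

For compound 4 a modestly lower number than compound 2 is expected, a 2.8-fold lower number from compound 2 to compound 4 (0.44 log units; beyond the scatter). Compound 4 is estimated at 2800 nM, with a range of 1000 nM to 8000 nM.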

Compound 4, half-maximal inhibitory concentration: 2300 nM
Compound 4: the middle estimate sits 1.2-fold (0.09 log units) above what was measured, within the range that was stated.
By their numbers in this assay, from the lowest: compounds 1, 4 and 3 (each within the scatter of the next); then compound 2.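

In this assay the exchange of bromo for methyl gives a 3.3-fold lower number from compound 2 to compound 4 (0.52 log units; beyond the scatter) and so extends the drop seen on leaving bromo from halogens to a carbon group. Methyl does not separate from the smaller halogens, with a 1.3-fold lower number from compound 3 to compound 4 (0.13 log units; within the scatter) and a 1.4-fold higher number from compound 1 to compound 4 (0.16 log units; within the scatter) both lying within the scatter, so among the four groups at this aromatic carbon only bromo stands apart. No measurement on hand accounts for this separation.

On these data alone, whether the flat level among methyl, chloro and fluoro extends to an amine, a methoxy group or a carboxylic acid at this aromatic carbon remains open. Also open, as far as these compounds go, is whether a longer chain, such as ethyl or propyl, behaves like methyl or moves the number up as bromo does.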